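The source may hold more compounds than are shown below. What is called first, only, known or untested is meant among the compounds shown, and "the series" means these compounds.

Of the compounds shown here, three built on a shared core have been measured in a functional assay on KB cells (Homo sapiens) for cytotoxicity, read by sulforhodamine B assay; a lower number here means a stronger inhibitor, a higher number a weaker inhibitor. Compound 1 `C=C1[C@@H](C/C=C2/C(=O)OC[C@H]2OC(C)=O)[C@]2(C)CC[C@@H](OC(C)=O)[C@@](C)(CO[Si](C)(C)C(C)(C)C)[C@H]2C[C@@H]1O` gives 9790 nM, compound 2 `C=C1[C@@H](OC(C)=O)C[C@@H]2[C@](C)(CO[Si](C)(C)C(C)(C)C)[C@H](OC(C)=O)CC[C@@]2(C)[C@@H]1C[C@@H](Nc1ccccc1F)C1=CCOC1=O` gives 4740 nM, and compound 3 `C=C1[C@@H](OC(C)=O)C[C@@H]2[C@](C)(COC=O)[C@H](OC(C)=O)CC[C@@]2(C)[C@@H]1C[C@@H](Nc1ccc(Br)cc1)C1=CCOC1=O` gives 24000 nM. On these numbers compound 3 stands highest, so in this assay it is the weakest inhibitor of the three; its gap to compound 1 and its larger gap to compound 2 both lie beyond the scatter of repeated measurements.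

Compound 4 `C=C1[C@@H](OC(C)=O)C[C@@H]2[C@](C)(COC=O)[C@H](OC(C)=O)CC[C@@]2(C)[C@@H]1C[C@@H](Nc1ccc(O)cc1)C1=CCOC1=O` has not yet been measured. It differs from compound 3 in a single place: hydroxy in place of bromo on an aromatic carbon. Within the data shown here, no pair of measured compounds here differs by such an exchange, so there is no measured step to lean on, and the change is small in size. The expected step is estimated as a 1.6-fold lower number from compound 3 to compound 4 (0.20 log units; within the scatter), a modest move that could well sit inside the scatter. Compound 4 is expected to give about 15000 nM in this assay, within a range of 5000 nM to 45000 nM.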

Compound 4, half-maximal inhibitory concentration: 28900 nM
Beside the measured number, compound 4's estimate is 1.9-fold (0.28 log units) below it; the range from low to high includes it.
By their numbers in this assay, from the lowest: compound 2; then compound 1; then compounds 3 and 4 (each within the scatter of the next).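

In this assay, replacing the (4-bromophenyl)amino group with (4-hydroxyphenyl)amino gives a 1.2-fold higher number from compound 3 to compound 4 (0.08 log units; within the scatter), so these two compounds cannot be told apart. Among these compounds, this is the only pair here that differs in one place, and it shows what the earlier comparisons could not: at this position on the aromatic ring, hydroxy, which adds a hydrogen-bond donor and a hydrogen-bond acceptor, reads the same as bromo, which has neither. Nothing given here explains this result.

The compounds shown leave open whether a different group at this position, such as an amine or a carboxylic acid, would move the number beyond the scatter. They also leave open whether the same exchange would read alike on the other compounds, which differ from compound 3 elsewhere in their structures.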